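Efficacy at the Dopamine D4 Receptor Across Three Anilides

The source may report more compounds than this note shows. Statements on the series, on what has been measured and on what is new or still open speak of the compounds shown alone.

Three compounds share one core and differ only in the aryl group on the amide nitrogen. Compound 1 `O=C(CN1CCC(c2cccc[n+]2[O-])CC1)Nc1ccc(F)cc1F` gives 74% in a functional assay on HEK293 cells for agonist activity at D(4) dopamine receptor (Homo sapiens), read by FLIPR (on this read-out lower numbers stand for smaller maximal responses and higher numbers for larger maximal responses), compound 2 `O=C(CN1CCC(c2cccc[n+]2[O-])CC1)Nc1cc(Cl)cc(Cl)c1` gives 68%, and compound 3 `CSc1cccc(NC(=O)CN2CCC(c3cccc[n+]3[O-])CC2)c1` gives 56%, the lowest of the three. The steps of a number 18 percentage points lower from compound 1 to compound 3 (beyond the scatter) and a number 12 percentage points lower from compound 2 to compound 3 (beyond the scatter) both mark compound 3 as the weakest responder, whereas a number 6 percentage points lower from compound 1 to compound 2 (within the scatter) is within the scatter. Compound 4 `Cc1cccc(C)c1NC(=O)CN1CCC(c2cccc[n+]2[O-])CC1` carries the change (2,6-dimethylphenyl in place of 3-(methylsulfanyl)phenyl on an amide-type nitrogen). Among the compounds with values here, no measured step involves a dimethylphenyl group, so the bearing steps only show that this position shifts efficacy modestly. Compound 4 is therefore expected to lie near the middle of the known range, with the step of a number 7 percentage points higher from compound 3 to compound 4 (within the scatter) estimated upward, giving 63% with a range from 46% to 80%.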

Compound 4, largest response reached (reported as efficacy), in percent of the reference or control that the assay uses: 68%
Compound 4: the middle estimate sits 5 percentage points below what was measured, within the range that was stated.
By their numbers in this assay, from the lowest: compound 3; then compounds 2, 4 and 1 (each within the scatter of the next).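

Swapping 3-(methylsulfanyl)phenyl for 2,6-dimethylphenyl gives a number 12 percentage points higher from compound 3 to compound 4 (beyond the scatter), showing that an aryl group of the same heavy-atom count, but without sulfur or a hydrogen-bond acceptor, can change the response at this amide-type nitrogen. The other two comparisons give no change at the digits printed from compound 2 to compound 4 (within the scatter) and a number 6 percentage points lower from compound 1 to compound 4 (within the scatter), so compound 3 alone stands apart among the four. Nothing available explains this difference. The compounds shown leave open how an aryl group bearing an amine or a carboxylic acid would respond.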